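The source may report more compounds than this note shows. Statements on the series, on what has been measured and on what is new or still open speak of the compounds shown alone.

Measured so far in a functional assay on MCF7 cells (Homo sapiens) for inhibition, read by MTT assay, with a stated time of 72 h; a lower number here means a stronger inhibitor, a higher number a weaker inhibitor:
- compound 1 `O=C(OC1(C(=O)Nc2ccc([N+](=O)[O-])cc2)CCCCC1)c1ccc(C(F)(F)F)cc1` gives 27.1 nM
- compound 2 `Cc1ccc(C(=O)OC2(C(=O)Nc3ccc([N+](=O)[O-])cc3)CCCCC2)cc1` gives 9.8 nM
- compound 3 `O=C(OC1(C(=O)Nc2ccc([N+](=O)[O-])cc2)CCCCC1)c1ccc(Br)cc1` gives 237 nM

Compound 3 stands at the highest number of the three and is the weakest inhibitor here: the step was an 8.7-fold higher number from compound 1 to compound 3 (0.94 log units; beyond the scatter) and a 24-fold higher number from compound 2 to compound 3 (1.38 log units; beyond the scatter). Compound 4 `O=C(OC1(C(=O)Nc2ccc([N+](=O)[O-])cc2)CCCCC1)c1ccccc1I` differs from compound 3 by 2-iodophenyl in place of 4-bromophenyl on a carbonyl carbon. For the measured compounds named here, both measured steps change the group carried by the aryl ring on the carbonyl carbon, but neither swaps one halogen for another or relocates it, so neither bears directly on this change; they show only that this ring is sensitive to what it carries. Compound 4 is therefore expected to land near compound 3, with a step of a 1.2-fold lower number from compound 3 to compound 4 (0.07 log units; within the scatter) in this assay and wide uncertainty. The estimate for compound 4 is 200 nM, within 50 nM to 800 nM.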

Compound 4, half-maximal inhibitory concentration: 619 nM
Beside the measured number, compound 4's estimate is 3.1-fold (0.49 log units) below it, and the stated range covers the measured number.
By their numbers in this assay, from the lowest: compound 2; then compound 1; then compound 3; then compound 4.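

In this assay, swapping one halogen-bearing aryl group for another on this carbonyl carbon still moves the result (a 2.6-fold higher number from compound 3 to compound 4 (0.42 log units; beyond the scatter)). Compound 4 also sits well above the two compounds without a halogen on the ring (a 63-fold higher number from compound 2 to compound 4 (1.80 log units; beyond the scatter); a 23-fold higher number from compound 1 to compound 4 (1.36 log units; beyond the scatter)), making it the weakest inhibitor of the four. No measurement shown explains this order. Going by these compounds, the halogen and its place on the ring change together here, so their separate contributions remain unknown. On these data alone, how an amine or a carboxylic acid on this ring would compare also remains open.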